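The source may hold more compounds than are shown below. What is called first, only, known or untested is meant among the compounds shown, and "the series" means these compounds.

Compound 1 `FC(F)(F)c1nc2c(-c3ccccc3)cccc2c(-c2ccccc2)c1-c1ccccc1` was tested in an assay for inhibition of ectonucleoside triphosphate diphosphohydrolase 3 (Homo sapiens), read by malachite green, with a stated time of 10 min; on this read-out higher numbers stand for weaker inhibition and lower numbers for stronger inhibition. In this assay compound 1 gives > 300000 nM, which is a limit of the assay rather than a measured number. Compound 2 `COc1ccc(-c2c(C(F)(F)F)nc3c(-c4ccc(OC)cc4)cccc3c2-c2ccc(OC)cc2)cc1` likewise gives > 300000 nM in this assay, again a limit. Both values sit at the same edge (the limit of > 300000 nM in this assay, at which 2 of the 2 values shown sit), so compound 1 cannot be placed above or below compound 2. Compound 3 `FC(F)(F)c1nc2c(-c3ccccc3)cccc2c(Cl)c1-c1ccccc1` carries chloro in place of phenyl on an aromatic carbon. Going by the values given here, with no measured step to lean on, the expected change from compound 1 to compound 3 is a number no higher from compound 1 to compound 3 (the limit leaves the size open), none beyond the scatter. Compound 3 is therefore estimated at 300000 nM, between 100000 nM and 1000000 nM.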

Compound 3, half-maximal inhibitory concentration: > 300000 nM
Compound 3 ended at the assay's limit (the forecaster's own chance of this, stated with the estimate: 80%); the middle value lies on the limit itself.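

Compound 1 and compound 3 both stand at a limit of the assay, so no step can be read between them: the limit of > 300000 nM in this assay, at which 3 of the 3 values shown sit.

The compounds shown leave open which change to the shared core, if any, would give a real measured number in this assay.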